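The source may report more compounds than this note shows. Statements on the series, on what has been measured and on what is new or still open speak of the compounds shown alone.

Measured in a functional assay on A549 cells (Homo sapiens) for cytotoxicity, read by MTT assay, with a stated time of 24 h, tested at 40 uM; on this read-out lower numbers stand for a stronger effect and higher numbers for a weaker effect at the one concentration tested:
Compound 1, `CCCOC(=O)CCC(=O)N1CCN(CCCOc2cc3c(Nc4ccc(F)c(Cl)c4)ncnc3cc2OC)CC1`: 80.9%
Compound 2, `CCCCOC(=O)CCC(=O)N1CCN(CCCOc2cc3c(Nc4ccc(F)c(Cl)c4)ncnc3cc2OC)CC1`: 79.1%
Compound 3, `CCCCCCCOC(=O)CCC(=O)N1CCN(CCCOc2cc3c(Nc4ccc(F)c(Cl)c4)ncnc3cc2OC)CC1`: 59.1%

Compound 4, `CCCCCCCCOC(=O)CCC(=O)N1CCN(CCCOc2cc3c(Nc4ccc(F)c(Cl)c4)ncnc3cc2OC)CC1`, has not yet been measured. It differs from compound 3 by methyl in place of hydrogen on a saturated chain carbon, seven bonds along the chain from an oxygen next to a carbonyl group. The same kind of change separates compound 1 from compound 2, (methyl in place of hydrogen on a saturated chain carbon, three bonds along the chain from an oxygen next to a carbonyl group), and there the step was a number 1.8 percentage points lower from compound 1 to compound 2 (within the scatter). The place is not the same: in the earlier pair the methyl enters three bonds along the chain from an oxygen next to a carbonyl group, in the new pair seven bonds along. The two cores differ by butyl in place of hydrogen on a saturated chain carbon, three bonds along the chain from an oxygen next to a carbonyl group, which gave a number 21.8 percentage points lower from compound 1 to compound 3 (beyond the scatter), and the related change gave a number 20 percentage points lower from compound 2 to compound 3 (beyond the scatter). The step from compound 3 to compound 4 is expected to be a number 6.1 percentage points lower from compound 3 to compound 4 (within the scatter), resting mostly on compound 1 and compound 2 with a number 1.8 percentage points lower from compound 1 to compound 2 (within the scatter), with some weight on compound 3 and a number 20 percentage points lower from compound 2 to compound 3 (beyond the scatter). Compound 4 is estimated at 53%, between 38% and 68%.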

Compound 4, a percentage reported as activity, at one concentration (the size of the read-out at that concentration, not a potency): 48.7%
Compound 4: middle estimate off by 4.3 percentage points, on the high side, and the stated range covers the measured number.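

Putting a methyl in place of a hydrogen on the saturated chain gave a number 10.4 percentage points lower from compound 3 to compound 4 (beyond the scatter) in this assay, and this change carries from one core to the other within the scatter: the same change on two cores in this assay, a number 1.8 percentage points lower (within the scatter) from compound 1 to compound 2 and a number 10.4 percentage points lower (beyond the scatter) from compound 3 to compound 4, 8.6 percentage points apart, within the scatter of two such steps

The longer additions gave a number 30.4 percentage points lower from compound 2 to compound 4 (beyond the scatter) and a number 32.2 percentage points lower from compound 1 to compound 4 (beyond the scatter), and butyl also carries across two cores: the same change on two cores in this assay, a number 21.8 percentage points lower (beyond the scatter) from compound 1 to compound 3 and a number 30.4 percentage points lower (beyond the scatter) from compound 2 to compound 4, 8.6 percentage points apart, within the scatter of two such steps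

Within the data shown here, this rests on only two pairs per change, so it shows agreement within the scatter, not that the steps are truly equal in size, and it gives no reason for them.

Going by these compounds, whether a chain longer than that of compound 4 would lower the number further remains open. So does the effect of a branched chain or of a carboxylic acid in place of the ester.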